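The compounds below may be only part of what the source reports. "The series", "measured", "known", "first", "only" and "open" are said of these compounds alone.

Three compounds sharing one core have been examined in an assay on isolated protein for displacement of a labelled ligand from metabotropic glutamate receptor 5 (Homo sapiens), with a stated time of 60 min, tested at 1 uM; a lower number here means less inhibition, a higher number more inhibition at the concentration tested (going by the name of the read-out). Compound 1 `CC1CCN(c2c(S(=O)(=O)c3ccc(F)cc3)cnc3ccc(F)cc23)CC1` gives 87% in this assay, compound 2 `CC1CCN(c2c(S(=O)(=O)c3ccc(Cl)c(Cl)c3)cnc3ccc(F)cc23)CC1` gives 91%, and compound 3 `CC1CCN(c2c(S(=O)(=O)c3ccc(Cl)cc3)cnc3ccc(F)cc23)CC1` gives 80%. Compound 3 stands at the lower end of these three numbers: the change a number 7 percentage points lower from compound 1 to compound 3 (within the scatter) is within the scatter, whereas the change a number 11 percentage points lower from compound 2 to compound 3 (beyond the scatter) is beyond it, so compound 3 is separated only from compound 2.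

Compound 4 `CC1CCN(c2c(S(=O)(=O)c3ccc(F)c(F)c3)cnc3ccc(F)cc23)CC1` has not yet been measured in this assay. It differs from compound 3 in one place: 3,4-difluorophenyl in place of 4-chlorophenyl on a sulfonyl sulfur.

Going by the values given here, two measured steps bear on this change. The step of a number 7 percentage points lower from compound 1 to compound 3 (within the scatter), read in reverse, suggests that returning fluorine for chlorine would, if anything, lift the number slightly, though within the scatter. The step of a number 4 percentage points higher from compound 1 to compound 2 (within the scatter) shows that adding a second halogen on the sulfonyl phenyl left the number essentially unchanged, while the step of a number 11 percentage points lower from compound 2 to compound 3 (beyond the scatter) shows a modest loss when that second halogen was removed. Taken together, a modest rise is expected for compound 4 rather than none, with the expected step being a number 8 percentage points higher from compound 3 to compound 4 (within the scatter). Compound 4 is therefore estimated to give 88% in this assay, with a range from 78% to 96%.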

Compound 4, a percentage reported as inhibition, at one concentration (the size of the read-out at that concentration, not a potency): 82%
Compound 4: the middle estimate sits 6 percentage points above what was measured, and the stated range covers the measured number.
By their numbers in this assay, from the lowest: compounds 3, 4, 1 and 2 (each within the scatter of the next, the first and the last beyond it).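

In this assay, the 3,4-difluorophenyl group on the sulfonyl sulfur cannot be told apart from any of the three earlier groups at this place: the steps are a number 2 percentage points higher from compound 3 to compound 4 (within the scatter), a number 5 percentage points lower from compound 1 to compound 4 (within the scatter) and a number 9 percentage points lower from compound 2 to compound 4 (within the scatter). The earlier compounds shown here held a single separation, between the 3,4-dichlorophenyl of compound 2 and the 4-chlorophenyl of compound 3, which could be read as a gain from a second halogen on this phenyl, but compound 4 also carries two halogens and is not separated from compound 3, so it goes against that reading. Nothing available explains why the two dihalogenated groups differ in their relation to compound 3.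

All four compounds carry a halogenated phenyl on the sulfonyl sulfur, which leaves open how the read-out would respond to an unsubstituted phenyl, or to a phenyl carrying a methoxy group, a nitrile or a carboxylic acid. As far as these compounds go, these numbers also give the size of the read-out at one concentration, so how the compounds would rank in potency remains open.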